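This account rests on a few compounds, and the source may have more. Where it says the series, first, only, none or still open, it means among the compounds named here.

Measured in a functional assay on the whole organism (strain Wistar) for inhibition, with Rattus norvegicus as the target, read by paw edema, with a stated time of 24 h, at a dose of 100 mg/kg; a lower number here means less inhibition, a higher number more inhibition at the dose given (going by the name of the read-out):

compound 1 `COc1cc2c(cc1OC)C(CC(=O)Nc1ccccc1)CC2` — 30%
compound 2 `COc1cc2c(cc1OC)C(CC(=O)Nc1ccc(Br)cc1)CC2` — 66.7%
compound 3 `COc1cc2c(cc1OC)C(CC(=O)Nc1ccc(C)cc1)CC2` — 30%

Compound 3 stands level with compound 1 at the digits printed, and the two together are the lowest of the three numbers. Within the data shown here, the only step beyond the scatter in this set is a number 36.7 percentage points lower from compound 2 to compound 3 (beyond the scatter); its mirror, a number 36.7 percentage points higher from compound 1 to compound 2 (beyond the scatter), is the same large move in the other direction. The step of no change at the digits printed from compound 1 to compound 3 (within the scatter) lies within the scatter.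

Compound 4 `COc1cc2c(cc1OC)C(CC(=O)Nc1ccncc1)CC2` is the next compound to be run. Its difference from compound 3 is pyridin-4-yl in place of 4-methylphenyl on an amide-type nitrogen. Among the measured compounds shown here, none of the measured steps carries a ring nitrogen in place of a ring carbon, so no step bears on this change directly. For the measured compounds named here, the one change that is known to be without effect is a methyl for hydrogen on the aromatic ring; the one large change is bromo for hydrogen. With nothing comparable in the data, the step to compound 4 is expected to fall within the scatter, a number 5 percentage points higher from compound 3 to compound 4 (within the scatter). Compound 4 is thus estimated at 35%, with a range from 15% to 60%.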

Compound 4, a percentage reported as inhibition, in the whole organism at one dose (the size of the read-out at that dose, not a potency): 46.7%
For compound 4 the middle estimate is 11.7 percentage points below the measured one, within the range that was stated.
By their numbers in this assay, from the lowest: compounds 1 and 3 (each within the scatter of the next); then compound 4; then compound 2.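

In this assay the group on the amide-type nitrogen responds to a change of the ring itself: pyridin-4-yl gives a number 16.7 percentage points higher from compound 3 to compound 4 (beyond the scatter) and likewise a number 16.7 percentage points higher from compound 1 to compound 4 (beyond the scatter) even though methyl in place of hydrogen on the aromatic ring moved nothing. The ring with a hetero atom still does not match the 4-bromophenyl group, with a number 20 percentage points lower from compound 2 to compound 4 (beyond the scatter) as the modest step on that side, so both substituted and unsubstituted carbon rings now have a measured comparison with pyridin-4-yl. No supporting data are available to account for these differences.

The compounds shown leave open whether pyridin-3-yl or pyridin-2-yl would match pyridin-4-yl. They also leave open how 4-chlorophenyl, or a phenyl ring carrying an amine or a carboxylic acid, would compare with the 4-bromophenyl group.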